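From cyclohexyl to isopropyl on the shared core

This account rests on a few compounds, and the source may have more. Where it says the series, first, only, none or still open, it means among the compounds named here.

Of the compounds shown here, two have been measured in an assay on isolated protein for binding affinity to Cholecystokinin receptor type A (Cavia porcellus), read by radioligand binding and CCK-8 assay; on this read-out lower numbers stand for stronger inhibition and higher numbers for weaker inhibition. Compound 1 `CN(C(=O)CN1C(=O)[C@H](NC(=O)Nc2cccc(Cl)c2)C[C@H](c2ccccc2)c2ccccc21)C(C)(C)C` gives 4.2 nM. Compound 2 `Cc1ccc2c(c1)N(CC(=O)NC(C)(C)C)C(=O)[C@H](NC(=O)Nc1cccc(Cl)c1)C[C@@H]2C1CCCCC1` gives 560 nM, the higher of the two numbers. Compound 3 `Cc1ccc2c(c1)N(CC(=O)NC(C)(C)C)C(=O)[C@H](NC(=O)Nc1cccc(Cl)c1)C[C@@H]2C(C)C` is not yet measured; it differs from compound 2 by isopropyl in place of cyclohexyl on a saturated ring carbon. Among the measured compounds shown here, no measured pair shows this change, so only a modest shift is expected in this assay, slightly toward weaker binding. The estimated step is a 1.4-fold higher number from compound 2 to compound 3 (0.15 log units; within the scatter). Compound 3 is expected at 800 nM, within 250 nM to 2500 nM.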

Compound 3, half-maximal inhibitory concentration: 72 nM
Estimate against measurement, compound 3: 11-fold (1.05 log units) above, outside the stated range (below it).
By their numbers in this assay, from the lowest: compound 1; then compound 3; then compound 2.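

In this assay, the saturated ring carbon two ring bonds from the ring atom bearing the ((3-chlorophenyl)carbamoyl)amino group proves sensitive to what it carries: isopropyl in place of cyclohexyl gives a 7.8-fold lower number from compound 2 to compound 3 (0.89 log units; beyond the scatter). Among the compounds shown here, this is the first single-place change seen on the shared core, and it lies beyond the scatter, so a ring is not needed here for stronger binding. No measurement on hand explains the step.

On these data alone, whether methyl or a longer chain such as n-butyl on this carbon would continue the trend remains open. Compound 1 differs from compound 3 in more than one place, so it cannot settle this.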